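Propyl for methyl on the aromatic nitrogen of a purine series

The source may report more compounds than this note shows. Statements on the series, on what has been measured and on what is new or still open speak of the compounds shown alone.

Compound 1 `CCCn1cnc2c(NC(c3ccccc3)c3ccccc3)nc(N[C@H](CC)CO)nc21` — > 100000 nM in a functional assay on tsA201 cells for agonist activity at Voltage-dependent N-type calcium channel subunit alpha-1B (Homo sapiens), read by patch clamp; on this read-out higher numbers stand for an effect only at larger amounts of compound and lower numbers for an effect already at smaller amounts
Compound 2 `CC[C@H](CO)Nc1nc(NC(c2ccccc2)c2ccccc2)c2ncn(C)c2n1` — > 100000 nM in this assay
Compound 3 `CC[C@H](CO)Nc1nc(NCc2ccc(C)s2)c2ncn(C)c2n1` — 30000 nM in this assay

Among the measured compounds shown here, the three measured compounds share a core, and compound 3 is the only one with a number in this assay. For compound 1 the value > 100000 nM is a limit of the assay and not a number. For compound 2 the value > 100000 nM is likewise a limit. Compound 3 gives 30000 nM. Compound 2 and compound 3 differ in more than one place; the difference between the two cores is not broken down here.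

Between compound 2 and compound 1 the change is ethyl in place of hydrogen on a saturated chain carbon bound to an aromatic nitrogen. Because both sit at the limit of > 100000 nM in this assay, at which 2 of the 3 values shown sit, the step that the two limits leave unreadable from compound 2 to compound 1 cannot be sized.

Compound 4 `CCCn1cnc2c(NCc3ccc(C)s3)nc(N[C@H](CC)CO)nc21`, not yet measured, carries the same change from compound 3: ethyl in place of hydrogen on a saturated chain carbon bound to an aromatic nitrogen. For the measured compounds named here, since the only earlier instance of this change is unreadable, an estimate for compound 4 can rest on compound 3 alone, and the step of no change at the digits printed from compound 3 to compound 4 (within the scatter) is expected to stay small. Compound 4 is therefore estimated at 30000 nM, most likely between 10000 nM and 100000 nM.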

Compound 4, half-maximal effective concentration: 7210 nM
Compound 4: the middle estimate sits 4.2-fold (0.62 log units) above what was measured; measured number outside the range, below it.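

In this assay, methyl to propyl on the aromatic nitrogen gives a 4.2-fold lower number from compound 3 to compound 4 (0.62 log units; beyond the scatter), so the change has a readable effect on this core, with the number moving downward. The same change on the other core cannot be sized, and that pair says nothing on whether the step carries over between cores, because compound 2 and compound 1 both sit at a limit of the assay: the limit of > 100000 nM in this assay, at which 2 of the 4 values shown sit. A single readable step on a single core shows neither that the lowering holds across this series nor how large it would be on any other core.

On these data alone, it remains open whether a longer chain such as butyl on the aromatic nitrogen would lower the number further, and whether ethyl there would give a value lying between those of methyl and propyl. Also open, as far as these compounds go, is what the hydroxyl of the side chain shared by all four compounds contributes, for instance when an amine stands in its place.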